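The source may report more compounds than this note shows. Statements on the series, on what has been measured and on what is new or still open speak of the compounds shown alone.

In a physicochemical assay for permeability, using PAMPA (on this read-out higher numbers stand for higher permeability and lower numbers for lower permeability), compound 1 (`Cc1oc(-c2ccc(Cl)cc2)nc1CN1CCC(C(=O)NCCCN2C[C@H](C)C[C@H](C)C2)CC1`) stands at > 635 10^-6 cm/s, which is a limit of the assay and not a number. Compound 2 (`Cc1ccccc1-c1nc(CN2CCC(C(=O)NCCCN3CCCCC3)CC2)c(C)o1`) gives a measured number, 34.5 10^-6 cm/s. Compound 3 (`Cc1oc(-c2c(Br)cccc2Br)nc1CN1CCC(C(=O)NCCCN2C[C@H](C)C[C@H](C)C2)CC1`) keeps the core of compound 1 and carries 2,6-dibromophenyl in place of 4-chlorophenyl on an aromatic carbon. Going by the values given here, no measured step covers this change. Compound 2 at 34.5 10^-6 cm/s shows only that this series can read much lower, so a downward move is tentatively expected, not a firm one. The expected step is an at least 2.8-fold lower number from compound 1 to compound 3 (0.46 log units; beyond the scatter). For compound 3 the estimated value is 220 10^-6 cm/s, with an expected range of 45 10^-6 cm/s to 800 10^-6 cm/s.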

Compound 3, apparent permeability: < 1 10^-6 cm/s
Compound 3 gave a limit, no number; the forecaster's own chance of this, stated with the estimate: 25%; at least 220-fold (2.34 log units) between middle value and limit.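

This position on the shared core is far from silent: with 2,6-dibromophenyl in place of 4-chlorophenyl, this assay shows an at least 630-fold lower number from compound 1 to compound 3 (2.80 log units; beyond the scatter). For compound 3 the result is a limit and not a number: the limit of < 1 10^-6 cm/s in this assay, at which 1 of the 3 values shown sits. For compound 1 the result is also a limit: the limit of > 635 10^-6 cm/s in this assay, at which 1 of the 3 values shown sits.

From the compounds shown here alone, the true size of the step stays open, with a limit at each end. Also open, going by these compounds, is whether the step follows the bromine atoms or their places on the phenyl ring, a question that 4-bromophenyl or 2,6-dichlorophenyl on the same carbon would address.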